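A few compounds are considered here, and "the series" means these few. Any claim that something is new, unique, unknown or untested is made for them only; others in the source may bear on it.

In a functional assay on SK-OV-3 cells (Homo sapiens) for antiproliferative activity, read by MTT assay, with a stated time of 72 h (on this read-out lower numbers stand for stronger inhibition and higher numbers for weaker inhibition), compound 1 `O=C(CCc1cccc2c1B(O)OC2)Nc1cccc(Br)c1` gives 540 nM, compound 2 `O=C(CCc1cccc2c1B(O)OC2)Nc1cccc(I)c1` gives 630 nM and compound 3 `C#Cc1cccc(NC(=O)CCc2cccc3c2B(O)OC3)c1` gives 980 nM. Compound 3 therefore stands within the scatter of both others. Compound 4 `O=C(CCc1cccc2c1B(O)OC2)Nc1cccc(-c2ccc(F)cc2)c1` carries 4-fluorophenyl in place of ethynyl on an aromatic carbon. Among the measured compounds shown here, the steps that bear on this change are a 1.2-fold higher number from compound 1 to compound 2 (0.07 log units; within the scatter), a 1.8-fold higher number from compound 1 to compound 3 (0.26 log units; within the scatter) and a 1.6-fold higher number from compound 2 to compound 3 (0.19 log units; within the scatter). All three stayed small, but none of them brought in a ring, so they cover this change only loosely. No step beyond the scatter is therefore expected in this assay, though the uncertainty is wide. The expected step is a 1.1-fold lower number from compound 3 to compound 4 (0.04 log units; within the scatter). For compound 4 the estimated value is 900 nM, with an expected range of 350 nM to 2500 nM.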

Compound 4, half-maximal inhibitory concentration: 93 nM
The estimate for compound 4 lay 9.7-fold (0.99 log units) above the measured number; measured number outside the range, below it.
By their numbers in this assay, from the lowest: compound 4; then compounds 1, 2 and 3 (each within the scatter of the next).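

In this assay, among the compounds shown here, this position, on an aromatic carbon, proves sensitive to its substituent: 4-fluorophenyl in place of ethynyl gives an 11-fold lower number from compound 3 to compound 4 (1.02 log units; beyond the scatter), a step beyond the scatter, which no earlier pair showed. In place of iodo it gives a 6.8-fold lower number from compound 2 to compound 4 (0.83 log units; beyond the scatter), and in place of bromo a 5.8-fold lower number from compound 1 to compound 4 (0.76 log units; beyond the scatter), so the ring-bearing group stands apart from all three earlier groups. Nothing shown gives a reason for this step. From the compounds shown here alone, whether the ring alone or its fluorine matters stays open, as does the outcome with an unsubstituted phenyl, a pyridine or an aminomethyl group here.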